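A few compounds are considered here, and "the series" means these few. Any claim that something is new, unique, unknown or untested is made for them only; others in the source may bear on it.

Compound 1 `COc1ccc(C2OC(c3cc(OC)c(OC)c(OC)c3)=NN2C(C)=O)c(OC)c1` belongs to a set of three measured compounds tested in a functional assay on BGC-823 cells (Homo sapiens) for antiproliferative activity, read by MTT assay, tested at 1 uM; a lower number here means a weaker effect, a higher number a stronger effect of the compound at the concentration tested. In this assay compound 1 gives 6.3%, the lowest of the three numbers; the nearest measured value is that of compound 2 `COc1cc(C(=O)N/N=C/c2ccccc2C(F)(F)F)cc(OC)c1OC`, which in this assay gives 22.1%, while compound 3 `COc1cc(C(=O)N/N=C/c2ccccc2F)cc(OC)c1OC` gives 51.6%, the furthest from compound 1. Both gaps from compound 1 lie beyond the scatter.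

Compound 4 `COc1cc(C2=NN(C(C)=O)C(c3ccccc3F)O2)cc(OC)c1OC` has not yet been measured. It differs from compound 1 in one place: 2-fluorophenyl in place of 2,4-dimethoxyphenyl on a saturated ring carbon. Going by the values given here, the only measured step within the set is a number 29.5 percentage points higher from compound 2 to compound 3 (beyond the scatter), which concerns a different change on an open-chain core, not the exchange of a whole aryl group on the saturated ring carbon of the core of compound 1, so it bears on the present step only loosely. Compound 3 carries the 2-fluorophenyl group that enters in compound 4, and its number is far higher than that of compound 1, but the two cores differ, so the direction of the step can only be guessed. A modest increase, a number 13.7 percentage points higher from compound 1 to compound 4 (beyond the scatter), is expected for compound 4, with wide uncertainty. Compound 4 is estimated to give 20% in this assay, likely between 5% and 45%.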

Compound 4, a percentage reported as inhibition, at one concentration (the size of the read-out at that concentration, not a potency): 29.6%
Compound 4: middle estimate off by 9.6 percentage points, on the low side; low and high end bracket the measured number.
By their numbers in this assay, from the lowest: compound 1; then compounds 2 and 4 (each within the scatter of the next); then compound 3.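

Going by these compounds alone, on the saturated ring carbon of the core of compound 1, 2-fluorophenyl in place of 2,4-dimethoxyphenyl gives, in this assay, a number 23.3 percentage points higher from compound 1 to compound 4 (beyond the scatter), the first sign that the aryl group at this position moves the number; the only earlier step concerned an open-chain core. The exchange changes several things at once, since the leaving group carries two methoxy groups and hydrogen-bond acceptors while the entering group carries a fluorine and no such acceptors, so the step cannot be assigned to the loss of the methoxy groups or to the gain of the fluorine alone. Nothing available explains the size or the direction of this step.

The compounds shown leave open whether an unsubstituted phenyl, a 2-methoxyphenyl or a 2-chlorophenyl on the same carbon would separate those contributions. They also leave open how much depends on the acetyl group on the ring nitrogen, which stays the same in both compounds and could be tested against a propanoyl group or a longer acyl chain.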